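The source may hold more compounds than are shown below. What is called first, only, known or untested is meant among the compounds shown, and "the series" means these compounds.

Within the data shown here, compound 1 `CCN(Cc1ccccn1)c1cccc(C(=O)N2CCc3ccc(OS(N)(=O)=O)cc3C2)c1` stands lowest of the two numbers measured so far: in an assay on HEK293 cells for inhibition of Steryl-sulfatase (Homo sapiens), tested at 0.1 uM (on this read-out higher numbers stand for a stronger effect at the one concentration tested and lower numbers for a weaker effect), compound 1 gives 6.5%. Compound 2 `CN(C)CCCN(Cc1ccccc1)c1cccc(C(=O)N2CCc3ccc(OS(N)(=O)=O)cc3C2)c1` gives 23.8% in this assay, a value that lies beyond the scatter from compound 1. Compound 3 `CC(C)CCN(CCC(C)C)c1cccc(C(=O)N2CCc3ccc(OS(N)(=O)=O)cc3C2)c1` has not been measured yet. It differs from compound 1 in one place (diisopentylamino in place of ethyl((pyridin-2-yl)methyl)amino on an aromatic carbon), on an aromatic carbon of a six-membered aromatic ring of carbon only, meta to a large group. Among the measured compounds shown here, no step between two measured compounds is known for guidance, so compound 3 is expected to stay close to compound 1, with a step of a number 5.5 percentage points higher from compound 1 to compound 3 (within the scatter) no larger than the scatter. Compound 3 is estimated at 12% in this assay, somewhere between 0% and 35%.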

Compound 3, a percentage reported as inhibition, at one concentration (the size of the read-out at that concentration, not a potency): 32.3%
Compound 3: the middle estimate sits 20.3 percentage points below what was measured; low and high end bracket the measured number.
By their numbers in this assay, from the lowest: compound 1; then compounds 2 and 3 (each within the scatter of the next).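

In this assay, putting diisopentylamino in place of ethyl((pyridin-2-yl)methyl)amino on this aromatic carbon gives a modest step, a number 25.8 percentage points higher from compound 1 to compound 3 (beyond the scatter), so the read-out responds to the group at this position. The pyridine ring is not needed here, as a group with no ring still gives a measurable effect. Nothing available accounts for this step.

The compounds shown do not separate losing the pyridine ring from gaining two isopentyl chains. A dibutylamino or plain amino group on the same carbon would help tell these apart.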